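This account rests on a few compounds, and the source may have more. Where it says the series, first, only, none or still open, it means among the compounds named here.

Measured in a functional assay on LNCaP cells (Homo sapiens) for antiproliferative activity; on this read-out lower numbers stand for stronger inhibition and higher numbers for weaker inhibition:
- Compound 1 `CNC(=O)C[C@@H]1C[C@@H](c2ccc(Cl)c(Cl)c2)[C@H](NC(=O)c2cc(-c3c(Cl)cnn3C)c(Cl)o2)CN1`: 40 nM
- Compound 2 `Cn1ncc(Cl)c1-c1cc(C(=O)N[C@@H]2CN[C@H](CC(O)CO)C[C@H]2c2ccc(Cl)c(Cl)c2)oc1Cl`: 70 nM
- Compound 3 `Cn1ncc(Cl)c1-c1cc(C(=O)N[C@@H]2CN[C@H](CC(N)=O)C[C@H]2c2ccc(Cl)c(Cl)c2)oc1Cl`: 160 nM

Of these three, compound 3 has the highest number, 160 nM, and its gaps to the other two lie beyond the scatter. Compound 4 `C=CC[C@@H]1C[C@@H](c2ccc(Cl)c(Cl)c2)[C@H](NC(=O)c2cc(-c3c(Cl)cnn3C)c(Cl)o2)CN1` differs from compound 3 by vinyl in place of carbamoyl on a saturated chain carbon bound to a saturated ring carbon. Within the data shown here, no measured compound carries vinyl there, so the evidence is indirect. The closest guides are the modest steps of a 2.3-fold higher number from compound 2 to compound 3 (0.36 log units; beyond the scatter) and a 4.0-fold higher number from compound 1 to compound 3 (0.60 log units; beyond the scatter), while a 1.8-fold higher number from compound 1 to compound 2 (0.24 log units; within the scatter) shows little separating the other two side chains. In this small set, both alternatives to the carbamoylmethyl of compound 3 give lower numbers, so a modest move towards a lower number is expected in this assay, though with real uncertainty. The expected change is a 2.0-fold lower number from compound 3 to compound 4 (0.30 log units; within the scatter). Compound 4 is estimated at 80 nM, with an expected range of 25 nM to 250 nM.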

Compound 4, half-maximal inhibitory concentration: 160 nM
Compound 4: middle estimate off by 2.0-fold (0.30 log units), on the low side, and the stated range covers the measured number.
By their numbers in this assay, from the lowest: compounds 1 and 2 (each within the scatter of the next); then compounds 3 and 4 (each within the scatter of the next).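

In this assay the step shows no change at the digits printed from compound 3 to compound 4 (within the scatter) when vinyl, with 0 hydrogen-bond donors and 0 hydrogen-bond acceptors, replaces carbamoyl, which has 1 of each, so this exchange on a saturated chain carbon bound to a saturated ring carbon leaves the number where it was. Against the other two side chains, allyl gives a 2.3-fold higher number from compound 2 to compound 4 (0.36 log units; beyond the scatter) for the change from 1,2-dihydroxyethyl and a 4.0-fold higher number from compound 1 to compound 4 (0.60 log units; beyond the scatter) for the change from methylcarbamoyl, so the lower numbers in this set belong to those two groups alone, and carbamoylmethyl and allyl both stand apart from them. Nothing measured here gives a reason for these steps.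

The compounds shown leave open what an amine or a carboxylic acid would give at this place. They also leave open whether a longer chain than allyl would stay level with compound 4 in this assay or move away from it.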